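Reshaping the Acyl Chain: From Compound 2 to Compound 3

The source may report more compounds than this note shows. Statements on the series, on what has been measured and on what is new or still open speak of the compounds shown alone.

Compound 1 (`CCCCC(=O)N(Cc1ccc(OC)c(O)c1)c1cc(OC)c(OC)c(OC)c1`) gives 66 nM in a functional assay on MGC-803 cells (Homo sapiens) for inhibition, read by MTT assay, with a stated time of 48 h; a higher number here means a weaker inhibitor, a lower number a stronger inhibitor
Compound 2 (`COc1ccc(CN(C(=O)C=C(C)C)c2cc(OC)c(OC)c(OC)c2)cc1O`) gives 320 nM in this assay

Compound 2 holds the higher of the two numbers, making it the weaker inhibitor of the pair. Compound 3 (`CC/C=C/C(=O)N(Cc1ccc(OC)c(O)c1)c1cc(OC)c(OC)c(OC)c1`) differs from compound 2 by a single change (but-1-en-1-yl in place of 2-methylprop-1-en-1-yl on a carbonyl carbon): but-1-en-1-yl in place of 2-methylprop-1-en-1-yl on a carbonyl carbon. The two have the same atoms, joined differently.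

Within the data shown here, only one measured step bears on this change. It is a 4.8-fold higher number from compound 1 to compound 2 (0.69 log units; beyond the scatter), a modest step beyond the scatter, in which 2-methylprop-1-en-1-yl replaced butyl at that same carbonyl carbon. Compound 3 keeps a double bond like compound 2, but its chain is unbranched like the butyl of compound 1. The data do not separate the branch from the double bond. A step smaller than the measured one is therefore expected, toward a lower number. In this assay the estimated step is (a 2.3-fold lower number from compound 2 to compound 3 (0.36 log units; beyond the scatter)). For compound 3 the expected value is 140 nM (estimated range 55 nM to 350 nM).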

Compound 3, half-maximal inhibitory concentration: 58 nM
Estimate against measurement, compound 3: 2.4-fold (0.38 log units) above; the range from low to high includes it.
By their numbers in this assay, from the lowest: compounds 3 and 1 (each within the scatter of the next); then compound 2.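

In this assay, straightening the chain while keeping its double bond gives a 5.5-fold lower number from compound 2 to compound 3 (0.74 log units; beyond the scatter), so the double bond alone does not account for the weaker inhibition of compound 2. The other new pair points the same way, with a 1.1-fold lower number from compound 1 to compound 3 (0.06 log units; within the scatter) placing the saturated butyl and the unsaturated but-1-en-1-yl chains level on this carbonyl carbon. Among these three compounds, the higher number therefore goes only with the branched 2-methylprop-1-en-1-yl group, and the isomeric pair of compound 2 and compound 3 shows that the arrangement of the chain's atoms matters here, not merely their number. Nothing available explains why the branched and unbranched chains differ in this way.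

From the compounds shown here alone, whether branching alone is enough remains open, as a saturated 2-methylpropyl group at this carbonyl carbon would be needed to test it against the 2-methylprop-1-en-1-yl group of compound 2. Also open, going by these compounds, is how far this position tolerates other shapes, such as a longer hexyl chain or a cyclopropyl ring, compared with the chains of compound 1 and compound 3.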